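A Fluorobenzyl Amide Next to Two Limit Values

The compounds below may be only part of what the source reports. "The series", "measured", "known", "first", "only" and "open" are said of these compounds alone.

Compound 3, `C=CC1=C(C(=O)NCC(C)C)C(c2ccc(OC)cc2)OC1`, is the isobutyl amide of a shared core. In a functional assay on HeLa cells (Homo sapiens) for cytotoxicity, read by MTT assay, with a stated time of 24 h (a higher number here means a weaker inhibitor, a lower number a stronger inhibitor), compound 3 reaches only a limit of the assay, > 100000 nM. Compound 1, `C=CC1=C(C(=O)NCc2ccccc2)C(c2ccc(OC)cc2)OC1`, the benzyl amide, likewise gives only a limit in this assay, > 100000 nM. Among the compounds with values here, compound 2, `C=CC1=C(C(=O)NCCC)C(c2ccc(OC)cc2)OC1`, carries a propyl chain, and in this assay compound 2 gives 14000 nM, the one real number among the three. The steps of an at least 7.1-fold lower number from compound 1 to compound 2 (0.85 log units; beyond the scatter) and an at least 7.1-fold higher number from compound 2 to compound 3 (0.85 log units; beyond the scatter) are both beyond the scatter, whereas the step that the two limits leave unreadable from compound 1 to compound 3 cannot be read, as both of its values sit at the limit of > 100000 nM in this assay, at which 2 of the 3 values shown sit.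

Compound 4, `C=CC1=C(C(=O)NCc2ccccc2F)C(c2ccc(OC)cc2)OC1`, differs from compound 3 by 2-fluorophenyl in place of isopropyl on a saturated chain carbon bound to an amide-type nitrogen. This change brings the amide substituent back toward the benzyl group of compound 1, with a fluorine added. The step most like it, a step that the two limits leave unreadable from compound 1 to compound 3, is unreadable, and both end points of that step are limits. The measured steps that give numbers, from the propyl amide of compound 2 outward, both run toward the limit. Compound 4 is therefore expected to show no step beyond the scatter from compound 3 and to remain at the limit, estimated as 100000 nM with a range of 30000 nM to 300000 nM. The expected step is a number no higher from compound 3 to compound 4 (the limit leaves the size open).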

Compound 4, half-maximal inhibitory concentration: > 100000 nM
Compound 4: a limit, no number (the forecaster's own chance of this, stated with the estimate: 75%); the middle value lies on the limit itself.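

Within the data shown here, with the 2-fluorobenzyl amide, a third substituent on the saturated chain carbon bound to an amide-type nitrogen gives no number, and the one step that can be read, an at least 7.1-fold higher number from compound 2 to compound 4 (0.85 log units; beyond the scatter), again runs from the propyl amide toward the limit. Putting fluoro in place of hydrogen on an aromatic carbon of the benzyl amide leaves compound 4 at the same limit as compound 1, so the steps joining compound 4 to compound 1 and to compound 3 cannot be read. The propyl amide of compound 2 now stands as the only amide with a real number in this assay, and the other three share one end of the scale: the limit of > 100000 nM in this assay, at which 3 of the 4 values shown sit.

On these data alone, how compound 1, compound 3 and compound 4 would order beyond that limit stays open, so nothing can be said about any difference among the benzyl, 2-fluorobenzyl and isobutyl amides. Also open, as far as these compounds go, is whether the value of compound 2 is particular to the propyl chain, or whether a butyl chain, or a chain ending in an amine or a carboxylic acid, would give a number at this place.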